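Pyridine for Pyrimidine on a Shorter Amide Linker

The source may hold more compounds than are shown below. What is called first, only, known or untested is meant among the compounds shown, and "the series" means these compounds.

Compound 1, `Cc1cccc(NC(=O)CCN2CCN(c3ccccn3)CC2)c1`, gives 1630 nM in a functional assay on cells for antagonist activity at D(4) dopamine receptor (Homo sapiens), read by TR-FRET and cAMP accumulation, with a stated time of 30 min; a higher number here means a weaker inhibitor, a lower number a stronger inhibitor.
Compound 2, `Cc1cccc(NC(=O)CCN2CCN(c3ncccn3)CC2)c1`, gives 2120 nM.
Compound 3, `Cc1cccc(NC(=O)CN2CCN(c3ncccn3)CC2)c1`, gives 463 nM.

All three carry the same aryl amide and a piperazine ring bearing a six-membered aromatic group. Between compound 2 and compound 1 the only change is pyridin-2-yl in place of pyrimidin-2-yl on an amine nitrogen in a ring, and it made a step of a 1.3-fold lower number from compound 2 to compound 1 (0.11 log units; within the scatter). Compound 3 differs from compound 2 in its core, which is shorter by one chain unit; the difference between the two cores is not broken down here. Compound 3 has the lowest number of the three, and its steps to compound 1 and to compound 2 both lie beyond the scatter.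

Compound 4, `Cc1cccc(NC(=O)CN2CCN(c3ccccn3)CC2)c1`, has not yet been measured. It arises from compound 3 by pyridin-2-yl in place of pyrimidin-2-yl on an amine nitrogen in a ring, the same change as that from compound 2 to compound 1, at the same place. Because the earlier step of a 1.3-fold lower number from compound 2 to compound 1 (0.11 log units; within the scatter) stayed within the scatter, a similarly small step a 1.2-fold lower number from compound 3 to compound 4 (0.06 log units; within the scatter) is expected here. Compound 4 is therefore estimated at 400 nM, most likely between 180 nM and 900 nM.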

Compound 4, half-maximal inhibitory concentration: 82.7 nM
The estimate for compound 4 lay 4.8-fold (0.68 log units) above the measured number, outside the stated range (below it).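

On the core of compound 3, pyridin-2-yl in place of pyrimidin-2-yl gave a 5.6-fold lower number from compound 3 to compound 4 (0.75 log units; beyond the scatter) in this assay, a clear improvement, whereas the same change on the longer core of compound 1 gave a step within the scatter. The size of this step therefore did not carry over from one core to the other: the same change on two cores in this assay, a 1.3-fold lower number (0.11 log units; within the scatter) from compound 2 to compound 1 and a 5.6-fold lower number (0.75 log units; beyond the scatter) from compound 3 to compound 4, 4.3-fold (0.63 log units) apart, beyond the scatter of two such steps

What this does not show is why the two cores respond so differently, and two pairs of compounds cannot predict the size of the step on any further core. It also means that a swap which seems to make little difference on one core should not be dismissed on another in this series.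

The compounds shown leave open whether a still longer chain in the core would shrink the step further, or whether a phenyl ring would do as well as pyridin-2-yl on the shorter core. As far as these compounds go, it also remains open whether a chlorine or methoxy group on the pyridin-2-yl ring of compound 4 would lower the number further.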